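Chloro for methoxy: from compound 1 to compound 4

This account rests on a few compounds, and the source may have more. Where it says the series, first, only, none or still open, it means among the compounds named here.

Measured in an assay on isolated protein for inhibition of alpha-ketoglutarate-dependent dioxygenase alkB homolog 3 (Homo sapiens), read by polymerase chain reaction, with a stated time of 1 h (a higher number here means a weaker inhibitor, a lower number a stronger inhibitor), so far:
- compound 1 `COc1ccc(Cc2c(C)[nH]n(-c3nc4ccccc4[nH]3)c2=O)cc1`: 630 nM
- compound 2 `Cc1[nH]n(-c2nc3ccccc3s2)c(=O)c1C`: > 10000 nM
- compound 3 `Cc1ccc2[nH]c(-n3[nH]c(C)c(Cc4ccc(-c5ccccc5)cc4)c3=O)nc2c1`: 5300 nM

Compound 1 gives the lowest of the two numbers in this assay, and compound 3, the nearest neighbour, sits above it by a gap that lies beyond the usual scatter. Compound 2 returns only a limit in this assay, not a number; it sits at the limit of > 10000 nM in this assay, at which 1 of the 3 values shown sits, and cannot be ranked against the other two.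

Among the compounds with values here, no pair of measured compounds differs in a single place, so no measured step is available to anchor the next change. Compound 4 `Cc1[nH]n(-c2nc3ccccc3[nH]2)c(=O)c1Cc1ccc(Cl)cc1` is derived from compound 1 by chloro in place of methoxy on an aromatic carbon. On the values shown nothing speaks for a large move in either direction, and the most defensible expectation is a change that stays within, or close to, the usual scatter, with a slight lean toward a somewhat higher number. The step from compound 1 to compound 4 in this assay is therefore expected to be a 1.3-fold higher number from compound 1 to compound 4 (0.10 log units; within the scatter). Compound 4 is estimated at 800 nM, with a plausible range from 250 nM to 2500 nM.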

Compound 4, half-maximal inhibitory concentration: > 10000 nM
Compound 4: only a limit was reported; the forecaster's own chance of this, stated with the estimate: 5%; middle value at least 12-fold (1.09 log units) from the limit.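

In this assay, within the data shown here, the 4-methoxyphenyl to 4-chlorophenyl exchange provides the first comparison between two compounds that differ in one place, and it gives an at least 15-fold higher number from compound 1 to compound 4 (1.20 log units; beyond the scatter). The position on the six-membered aromatic ring, para to a large group, therefore does not tolerate every substituent, and with the rest of compound 1 unchanged, this single exchange is enough to take the reading to the limit of the assay. Compound 4 is recorded only as a limit, not a number, so the step has a lower bound but no upper one: the limit of > 10000 nM in this assay, at which 2 of the 4 values shown sit.

The methoxy that leaves carries one hydrogen-bond acceptor and the chloro that enters carries none, but a single pair cannot show whether that difference matters or whether something else about the exchange accounts for the loss. Ethoxy, hydroxy, fluoro or dimethylamino at the same place, or a phenyl ring with no substituent there, would be needed to separate these readings, and the shown compounds include none of them.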